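A few compounds are considered here, and "the series" means these few. Any claim that something is new, unique, unknown or untested is made for them only; others in the source may bear on it.

In a functional assay on MDA-MB-231 cells (Homo sapiens) for cytotoxicity, read by MTT assay, with a stated time of 48 h (a lower number here means a stronger inhibitor, a higher number a weaker inhibitor), compound 1 `COc1cc(/C=C/c2ccc(OCCCC(=O)NO)cc2)cc(OC)c1` gives 3890 nM, compound 2 `COc1cc(/C=C/c2ccc(OCCCCCC(=O)NO)cc2)cc(OC)c1` gives 3560 nM, and compound 3 `COc1cc(/C=C/c2ccc(OCCCCCCC(=O)NO)cc2)cc(OC)c1` gives 780 nM, the lowest of the three numbers. Compound 4 `COc1cc(/C=C/c2ccc(OCCCCCCCC(=O)NO)cc2)cc(OC)c1` remains unmeasured and differs from compound 3 by (hydroxycarbamoyl)methyl in place of hydroxycarbamoyl on a saturated chain carbon, six bonds along the chain from an oxygen on an aromatic ring. Among the compounds with values here, the closest precedent is the same replacement made five bonds along the chain, a 4.6-fold lower number from compound 2 to compound 3 (0.66 log units; beyond the scatter), a modest step beyond the scatter. The longer extension a 5.0-fold lower number from compound 1 to compound 3 (0.70 log units; beyond the scatter) is of similar size, but a 1.1-fold lower number from compound 1 to compound 2 (0.04 log units; within the scatter) lies within the scatter, so lengthening the chain does not lower the number at every step. Only a small further drop is expected, a 1.2-fold lower number from compound 3 to compound 4 (0.08 log units; within the scatter), which means no expected change beyond the scatter. The estimate for compound 4 is 650 nM, with an expected range of 250 nM to 1700 nM.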

Compound 4, half-maximal inhibitory concentration: 5050 nM
Estimate against measurement, compound 4: 7.8-fold (0.89 log units) below; measured number above the stated range.
By their numbers in this assay, from the lowest: compound 3; then compounds 2, 1 and 4 (each within the scatter of the next).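

In this assay, the replacement that lowered the number five bonds along the chain reverses six bonds along (a 6.5-fold higher number from compound 3 to compound 4 (0.81 log units; beyond the scatter)), so the gain with chain length ends at compound 3. Compound 4 instead sits level with the shorter chains (a 1.4-fold higher number from compound 2 to compound 4 (0.15 log units; within the scatter); a 1.3-fold higher number from compound 1 to compound 4 (0.11 log units; within the scatter)), which leaves compound 3 alone as the lowest number of the four. No evidence here bears on this reversal. Still open, from the compounds shown here alone, is how a longer chain would read, and whether a carboxylic acid in place of the hydroxycarbamoyl end would keep any of the number seen with compound 3.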